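The compounds below may be only part of what the source reports. "The series", "measured", "known", "first", "only" and "open" are said of these compounds alone.

Measured in an assay on ileum for antagonist activity at 5-hydroxytryptamine receptor 3A (Cavia porcellus); on this read-out lower numbers stand for stronger inhibition and higher numbers for weaker inhibition:
compound 1 `COc1ccc(N2CCN(CCCN3CCN(c4ncccc4C#N)CC3)CC2)cc1` — 3000 nM
compound 2 `COc1ccccc1N1CCN(CCN2CCN(c3ncccc3C#N)CC2)CC1` — > 10000 nM, which is a limit of the assay and not a number

Going by the values given here, compound 2 thus stands only at the limit of > 10000 nM in this assay, at which 1 of the 2 values shown sits, so no step between the two measured compounds can be sized. Compound 3 `N#Cc1cccnc1N1CCN(CCN2CCN(c3cccc(Cl)c3Cl)CC2)CC1` differs from compound 2 by 2,3-dichlorophenyl in place of 2-methoxyphenyl on an amine nitrogen in a ring. Nothing measured here fixes the effect of that exchange; the expected step from compound 2 to compound 3 is an at least 1.2-fold lower number from compound 2 to compound 3 (0.09 log units; that floor lies within the scatter), and a fair chance remains that this assay again returns only a limit. Compound 3 is estimated at 8000 nM, within 2000 nM to 30000 nM.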

Compound 3, half-maximal inhibitory concentration: 1000 nM
The estimate for compound 3 lay 8.0-fold (0.90 log units) above the measured number; measured number below the stated range.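

In this assay, this amine nitrogen in a ring is a place where a single exchange registers: 2,3-dichlorophenyl in place of 2-methoxyphenyl gives an at least 10-fold lower number from compound 2 to compound 3 (1.00 log units; beyond the scatter). The printed step is a floor rather than a full size, because compound 2 stands only at a limit of the assay and not at a number: the limit of > 10000 nM in this assay, at which 1 of the 3 values shown sits.

Going by these compounds, whether a single chlorine, as in 2-chlorophenyl or 3-chlorophenyl, would give the same step remains open, as does the result for unsubstituted phenyl at this place. Compound 1 differs from compound 3 in more than one place, so it does not settle the role of the chain.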